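Swapping a Chain-End Ring on a Cytotoxic Core

The compounds below may be only part of what the source reports. "The series", "measured", "known", "first", "only" and "open" are said of these compounds alone.

Measured so far:
compound 1 `CC1(C)OCC(Cn2cc(Cn3c4c(c5ccccc53)C(=O)c3c[n+]([O-])c5ccccc5c3C4=O)nn2)O1` gives 230 nM
compound 2 `O=C1c2c[n+]([O-])c3ccccc3c2C(=O)c2c1c1ccccc1n2CCCCN1CCNCC1` gives 1240 nM

In a functional assay on SH-SY5Y cells (Homo sapiens) for cytotoxicity, read by MTT assay, with a stated time of 72 h (a higher number here means a weaker inhibitor, a lower number a stronger inhibitor), compound 2 stands at the higher of the two numbers, the weaker of the pair; the nearest value, that of compound 1, sits well beyond the scatter, so the two differ in earnest. The two compounds share a core but differ in several places at once, so their values show only that one is the weaker, not what any single change does.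

Compound 3 `O=C1c2c[n+]([O-])c3ccccc3c2C(=O)c2c1c1ccccc1n2CCCN1CCC(O)CC1` differs from compound 2 in one place: 4-hydroxypiperidin-1-yl in place of (piperazin-1-yl)methyl on a saturated chain carbon, three bonds along the chain from an aromatic nitrogen. Among the compounds with values here, no measured pair shows this change, so the expectation rests on compound 2 alone. The step of a 1.2-fold lower number from compound 2 to compound 3 (0.09 log units; within the scatter) is expected to be small, not beyond the scatter. Compound 3 is therefore estimated at about 1000 nM, with a range from 400 nM to 2500 nM.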

Compound 3, half-maximal inhibitory concentration: 130 nM
Compound 3: middle estimate off by 7.7-fold (0.89 log units), on the high side; measured number below the stated range.
By their numbers in this assay, from the lowest: compounds 3 and 1 (each within the scatter of the next); then compound 2.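

In this assay the end of this chain turns out to matter: exchanging (piperazin-1-yl)methyl for 4-hydroxypiperidin-1-yl gives a 9.5-fold lower number from compound 2 to compound 3 (0.98 log units; beyond the scatter) and not the small step that might have been expected. The two groups have equal counts of heavy atoms, hydrogen-bond donors and acceptors, and neither carries a net charge, so these counts alone do not predict the result at this position. Nothing measured here explains the drop in the number.

As far as these compounds go, it remains open whether the ring or the chain length accounts for the step, as the change also reads 4-(piperazin-1-yl)butyl to 3-(4-hydroxypiperidin-1-yl)propyl. A 3-(piperazin-1-yl)propyl group would separate those two changes, and a plain piperidine or a morpholine at the chain end would test the part played by the hydroxyl.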